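The source may hold more compounds than are shown below. What is called first, only, known or untested is meant among the compounds shown, and "the series" means these compounds.

Measured in a functional assay on MDA-MB-231 cells (Homo sapiens) for cytotoxicity, read by MTT assay, with a stated time of 72 h; on this read-out lower numbers stand for stronger inhibition and higher numbers for weaker inhibition:
Compound 1 `Cc1ccc(NC(=O)CN2CCN(c3nnc(Cc4ccncc4)c4ccccc34)CC2)c(C)c1`: 240 nM
Compound 2 `O=C(CN1CCN(c2nnc(Cc3ccncc3)c3ccccc23)CC1)Nc1cccc(F)c1`: 4.4 nM
Compound 3 `Cc1ccc(F)cc1NC(=O)CN1CCN(c2nnc(Cc3ccncc3)c3ccccc23)CC1`: 6.4 nM

Compound 3 lies within the scatter of compound 2, and its number is far lower than that of compound 1. Compound 4 `O=C(CN1CCN(c2nnc(Cc3ccncc3)c3ccccc23)CC1)Nc1ccc(F)c(Cl)c1` differs from compound 3 as follows: 3-chloro-4-fluorophenyl in place of 5-fluoro-2-methylphenyl on an amide-type nitrogen. The measured steps at this amide-type nitrogen are large for a 55-fold lower number from compound 1 to compound 2 (1.74 log units; beyond the scatter) and for a 38-fold lower number from compound 1 to compound 3 (1.57 log units; beyond the scatter), while a 1.5-fold higher number from compound 2 to compound 3 (0.16 log units; within the scatter) stays within the scatter. Within the data shown here, no measured compound carries the 3-chloro-4-fluorophenyl group, so a small upward step in this assay is expected, possibly none beyond the scatter. The expected step is a 1.7-fold higher number from compound 3 to compound 4 (0.24 log units; within the scatter). For compound 4 the estimated value is 11 nM, with an expected range of 3 nM to 70 nM.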

Compound 4, half-maximal inhibitory concentration: 4 nM
Compound 4: the middle estimate sits 2.8-fold (0.44 log units) above what was measured, and the stated range covers the measured number.
By their numbers in this assay, from the lowest: compounds 4, 2 and 3 (each within the scatter of the next); then compound 1.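

In this assay, a second halogen on the ring at the amide-type nitrogen brings no separable change: the 3-chloro-4-fluorophenyl group gives a 1.6-fold lower number from compound 3 to compound 4 (0.20 log units; within the scatter) and a 1.1-fold lower number from compound 2 to compound 4 (0.04 log units; within the scatter). The gap to the 2,4-dimethylphenyl group stays wide, with a 60-fold lower number from compound 1 to compound 4 (1.78 log units; beyond the scatter), so all three fluorine-bearing rings stand apart from the one ring without fluorine. No supporting data bear on why this is so. The compounds shown leave open whether an amine or a carboxylic acid on this ring would keep such low numbers. They also leave open how a longer chain between the amide-type nitrogen and the ring would read.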